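The source may hold more compounds than are shown below. What is called first, only, known or untested is meant among the compounds shown, and "the series" means these compounds.

Measured so far in a functional assay on RAW264.7 cells (Mus musculus) for inhibition, read by Griess assay, with stated times of 2 h and 24 h; on this read-out higher numbers stand for weaker inhibition and lower numbers for stronger inhibition:
compound 1 `COc1ccc([C@@H]2CC(=O)c3c(O)cc(OCc4cn(Cc5ccc(C(F)(F)F)cc5)nn4)cc3O2)cc1O` gives 17700 nM;
compound 2 `COc1ccc([C@@H]2CC(=O)c3c(O)cc(OCc4cn(C)nn4)cc3O2)cc1O` gives 15200 nM;
compound 3 `COc1ccc([C@@H]2CC(=O)c3c(O)cc(OCc4cn(Cc5cccc(C(F)(F)F)c5)nn4)cc3O2)cc1O` gives 19900 nM.

Compound 3 sits with the other two: the steps of a 1.1-fold higher number from compound 1 to compound 3 (0.05 log units; within the scatter) and a 1.3-fold higher number from compound 2 to compound 3 (0.12 log units; within the scatter) both lie within the scatter, so no ordering among the three can be claimed. Compound 4 `COc1ccc([C@@H]2CC(=O)c3c(O)cc(OCc4cn(Cc5ccccc5C)nn4)cc3O2)cc1O` differs from compound 3 by 2-methylphenyl in place of 3-(trifluoromethyl)phenyl on a saturated chain carbon bound to an aromatic nitrogen. Among the measured compounds shown here, the steps that bear on this place, a 1.2-fold lower number from compound 1 to compound 2 (0.07 log units; within the scatter), a 1.1-fold higher number from compound 1 to compound 3 (0.05 log units; within the scatter) and a 1.3-fold higher number from compound 2 to compound 3 (0.12 log units; within the scatter), all stayed within the scatter, so the group on this saturated chain carbon has so far left this assay unchanged. Compound 4 is therefore expected to give 18000 nM, between 9000 nM and 36000 nM, a step of a 1.1-fold lower number from compound 3 to compound 4 (0.04 log units; within the scatter) that is expected to stay within the scatter.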

Compound 4, half-maximal inhibitory concentration: 13100 nM
Beside the measured number, compound 4's estimate is 1.4-fold (0.14 log units) above it, and the stated range covers the measured number.
By their numbers in this assay, from the lowest: compounds 4, 2, 1 and 3 (each within the scatter of the next).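

In this assay the 2-methylbenzyl group also leaves the number within the scatter of all three earlier groups on this saturated chain carbon (a 1.5-fold lower number from compound 3 to compound 4 (0.18 log units; within the scatter)) (a 1.2-fold lower number from compound 2 to compound 4 (0.06 log units; within the scatter)) (a 1.4-fold lower number from compound 1 to compound 4 (0.13 log units; within the scatter)). A methyl-bearing ring therefore joins hydrogen and both trifluoromethyl-bearing rings in showing no separable difference across these four compounds. Nothing measured here accounts for this result. The compounds shown leave open whether an amine or a carboxylic acid on this carbon would move the number. They also leave open whether a change elsewhere on the shared core would do so.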